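The compounds below may be only part of what the source reports. "The series", "measured", "known", "first", "only" and "open" are said of these compounds alone.

Measured compounds in a functional assay on MCF7 cells (Homo sapiens) for antiproliferative activity, read by MTT assay, with a stated time of 48 h; on this read-out higher numbers stand for weaker inhibition and lower numbers for stronger inhibition: compound 1 `O=C(Nc1cccc(/C=C/C(=O)c2nc3ccccc3[nH]2)c1)c1ccc(Br)cc1` with 7000 nM, and compound 2 `COc1ccc(C(=O)Nc2cccc(/C=C/C(=O)c3nc4ccccc4[nH]3)c2)cc1` with 20100 nM.

Compound 2 gives the highest of the two numbers; the nearest is compound 1, and the difference is a 2.9-fold higher number from compound 1 to compound 2 (0.46 log units; beyond the scatter). Compound 3 `Cc1ccc(S(=O)(=O)Nc2cccc(/C=C/C(=O)c3nc4ccccc4[nH]3)c2)cc1` differs from compound 2 in one place: (4-methylphenyl)sulfonyl in place of (4-methoxyphenyl)carbonyl on a nitrogen on an aromatic ring. Going by the values given here, no measured step changes this part of the molecule, so the one known step offers no guide, and the expectation is wide. The estimate for compound 3 is 15000 nM (range 4000 nM to 50000 nM), corresponding to an expected step of a 1.3-fold lower number from compound 2 to compound 3 (0.13 log units; within the scatter), which is taken as no change beyond the scatter.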

Compound 3, half-maximal inhibitory concentration: 3220 nM
The estimate for compound 3 lay 4.7-fold (0.67 log units) above the measured number; the measured number lies below the stated range.
By their numbers in this assay, from the lowest: compound 3; then compound 1; then compound 2.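

On this nitrogen, the change to (4-methylphenyl)sulfonyl lowers the number in this assay against both amide partners (a 6.2-fold lower number from compound 2 to compound 3 (0.80 log units; beyond the scatter); a 2.2-fold lower number from compound 1 to compound 3 (0.34 log units; beyond the scatter)). Going by these compounds alone, the first changes at this position thus show that the group on this nitrogen can be replaced without losing activity. No evidence on why this happens is available.

On these data alone, each step swaps the carbonyl link and the ring substituent together, so their separate shares remain unknown. As far as these compounds go, it also remains open how a sulfonyl carrying 4-bromophenyl, or a methylsulfonyl group without a ring, would behave.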